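This account rests on a few compounds, and the source may have more. Where it says the series, first, only, none or still open, it means among the compounds named here.

Measured in a functional assay on PANC-1 cells (Homo sapiens) for cytotoxicity, read by MTT assay, with a stated time of 72 h; on this read-out higher numbers stand for weaker inhibition and lower numbers for stronger inhibition:
compound 1, `O=C1C=CC(=O)c2ncncc21`, gives 18000 nM
compound 2, `O=C1C(Nc2ccc(Oc3ccccc3)cc2)=CC(=O)c2ncncc21`, gives 1800 nM
compound 3, `COc1cccc(NC2=CC(=O)c3ncncc3C2=O)c1`, gives 600 nM

Compound 1 is the bare shared core, and it gives the highest number of the three. Compound 2 and compound 3 each carry an extra group on that core, and both give lower numbers. Compound 2 stands second highest: its gap to compound 1 is beyond the scatter, and its gap to compound 3, which gives the lowest number, is also beyond the scatter.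

Compound 4, `O=C1C(Nc2ccc(OC(F)(F)F)cc2)=CC(=O)c2ncncc21`, has not yet been measured in this assay. It differs from compound 2 in one place: trifluoromethyl in place of phenyl on an oxygen on an aromatic ring. Cut one bond further out, the same change reads phenoxy to trifluoromethoxy. Among the measured compounds shown here, no measured pair shows this change on this core, so there is no step to lean on. Compound 3 shows that another small group on the attached ring can give a lower number than compound 2, but it is a different group, so it does not say how this change will read. The expectation for compound 4 is a small step, likely within the scatter, in either direction a 1.2-fold lower number from compound 2 to compound 4 (0.08 log units; within the scatter). Compound 4 is estimated at 1500 nM, with a range from 500 nM to 4500 nM.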

Compound 4, half-maximal inhibitory concentration: 900 nM
Beside the measured number, compound 4's estimate is 1.7-fold (0.22 log units) above it; low and high end bracket the measured number.
By their numbers in this assay, from the lowest: compounds 3, 4 and 2 (each within the scatter of the next, the first and the last beyond it); then compound 1.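

In this assay, putting trifluoromethyl in place of phenyl on an oxygen on an aromatic ring gives a 2.0-fold lower number from compound 2 to compound 4 (0.30 log units; within the scatter), so the two numbers cannot be told apart. This is the first pair shown that differs in one place only, and it indicates that, on this core, the six-carbon aromatic ring at the end of the phenoxy group is not required to keep the number at this level: a group of four heavy atoms with no ring at all reads the same within the scatter. Nothing available accounts for this result, so it stands as an observation about this one pair.

The compounds shown leave open whether the outer group matters at all at this place, as a plain methyl on the same oxygen or a longer chain such as butyl could show. They also leave open whether the oxygen itself can be exchanged, for instance by an amine such as dimethylamino in place of the whole trifluoromethoxy group.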